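Cytotoxicity Limits in a Sulfonamide Series: Compound 4

The source may hold more compounds than are shown below. What is called first, only, known or untested is meant among the compounds shown, and "the series" means these compounds.

Compound 1 `Cc1cc(C)c(S(=O)(=O)N2CCC(N3CCC(C(C)C)CC3)CC2)c(C)c1` gives > 5000 nM in an ADME assay on HCT-116 cells (Homo sapiens) for cytotoxicity, read by CellTiter-Glo, with a stated time of 72 h (a lower number here means a stronger inhibitor, a higher number a weaker inhibitor), a limit rather than a number. Compound 2 `Cc1cc(C)c(S(=O)(=O)N2CCC(N3CCC(C)OC3)CC2)c(C)c1` gives > 5000 nM, also a limit. Compound 3 `Cc1ccc(C2CCN(S(=O)(=O)c3c(C)cc(C)cc3C)CC2)cc1` gives > 5000 nM, again a limit.

Compound 1 therefore stands only at the limit of this assay, alongside every other value shown (the limit of > 5000 nM in this assay, at which 3 of the 3 values shown sit). The new compound, compound 4 `Cc1cc(C)c(S(=O)(=O)N2CCC(N3CCC(CCC#N)CC3)CC2)c(C)c1`, changes it as follows: 2-cyanoethyl in place of isopropyl on a saturated ring carbon. The measured steps from compound 1 are a step that the two limits leave unreadable from compound 1 to compound 2 and a step that the two limits leave unreadable from compound 1 to compound 3, and neither can be read in size, so they set no direction for the new change. With all three values sitting at the limit, a step beyond the scatter is not expected, and compound 4 is expected to remain at the limit, about a step that the limit leaves unreadable from compound 1 to compound 4. The estimate for compound 4 is 8000 nM, between 3000 nM and 25000 nM.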

Compound 4, half-maximal inhibitory concentration: > 5000 nM
Compound 4 ended at the assay's limit; the forecaster's own chance of this, stated with the estimate: 85%; the middle value does not contradict the limit.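

Compound 1 and compound 4 both stand at a limit rather than a number, so the size of the step between them cannot be read: the limit of > 5000 nM in this assay, at which 4 of the 4 values shown sit.

The compounds shown leave open what real value any of them has in this assay, and whether any change to the shared core would give a readable number.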